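The source may report more compounds than this note shows. Statements on the series, on what has been measured and on what is new or still open speak of the compounds shown alone.

Among the measured compounds shown here, in a functional assay on HT-22 cells (Mus musculus), read by MTT assay, with a stated time of 24 h (on this read-out lower numbers stand for an effect already at smaller amounts and higher numbers for an effect only at larger amounts of compound), compound 3 `COc1cc(-c2cc(OC)c3ccccc3n2)ccc1O` gives 500 nM, the higher of the only two numbers available. Compound 2 `COc1cc(-c2ccc(O)c(O)c2)nc2ccccc12` gives 40 nM, while compound 1 `CCOc1ccc(-c2cc(OC)c3ccccc3n2)cc1OCC` is reported as "not active" (no number reported), with no number. Still unmeasured is compound 4 `COc1cc(-c2ccc(O)cc2)nc2ccccc12`, which differs from compound 3 in one place: hydrogen in place of methoxy on an aromatic carbon. Hydrogen takes the place of methoxy on an aromatic carbon, ortho to a hydroxy group, and compound 4 keeps that hydroxy group.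

For the measured compounds named here, only one measured step bears on this change. That step, a 13-fold higher number from compound 2 to compound 3 (1.10 log units; beyond the scatter), is large, but it is methyl in place of hydrogen on an oxygen, not the loss of a whole methoxy, so it is only a loose guide. It shows that a small change on this ring can count in this assay, yet it does not settle the direction here. No step beyond the scatter is therefore expected, and the estimate is a 1.7-fold lower number from compound 3 to compound 4 (0.22 log units; within the scatter). For compound 4 the expected value is 300 nM, within an estimated range of 60 nM to 1500 nM.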

Compound 4, half-maximal effective concentration: "not active" (no number reported)
Nothing numeric was reported for compound 4; the estimate stays without a comparison.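

Among the compounds shown here, compound 4 is reported as "not active" (no number reported) in this assay, so no step from compound 3 to compound 4 can be read. The compounds shown leave open how much the methoxy of compound 3 counts in numbers. No measurement given here explains this result.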